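Sulfonyl aryl substituent swap: chloro to methyl

The source may report more compounds than this note shows. Statements on the series, on what has been measured and on what is new or still open speak of the compounds shown alone.

In a functional assay (Cavia porcellus) with sulfonylurea receptors; K-ATP channels (Homo sapiens) as the target (on this read-out lower numbers stand for stronger inhibition and higher numbers for weaker inhibition), compound 2 `CC(O)(C(=O)Nc1ccc(S(=O)(=O)c2cccc(Cl)c2)cc1)C(F)(F)F` gives 10000 nM and stands level with compound 1 `CC(O)(C(=O)Nc1ccc(S(=O)(=O)c2ccc(F)cc2)cc1)C(F)(F)F`, which gives 8600 nM; the step of a 1.2-fold higher number from compound 1 to compound 2 (0.07 log units; within the scatter) is within the scatter. Compound 3 `Cc1cccc(S(=O)(=O)c2ccc(NC(=O)C(C)(O)C(F)(F)F)cc2)c1` is not yet measured and differs from compound 2 by methyl in place of chloro on an aromatic carbon. Among the compounds with values here, the one measured step on this aryl ring, a 1.2-fold higher number from compound 1 to compound 2 (0.07 log units; within the scatter), is the only bearing case, and it was small, so a change beyond the scatter is not expected in this assay. Compound 3 is estimated at 10000 nM, with a range of 4000 nM to 25000 nM. The expected step is no change at the digits printed from compound 2 to compound 3 (within the scatter).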

Compound 3, half-maximal inhibitory concentration: 2200 nM
Beside the measured number, compound 3's estimate is 4.5-fold (0.66 log units) above it, and the stated range ends above it.
By their numbers in this assay, from the lowest: compound 3; then compounds 1 and 2 (each within the scatter of the next).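

In this assay the aryl ring on the sulfonyl sulfur proves sensitive to its substituent: methyl in place of chloro gives a 4.5-fold lower number from compound 2 to compound 3 (0.66 log units; beyond the scatter) where the earlier pair showed no step beyond the scatter. The 3-methylphenyl ring also parts from the 4-fluorophenyl ring, with a 3.9-fold lower number from compound 1 to compound 3 (0.59 log units; beyond the scatter), so among these three compounds the lower number goes with methyl, while compound 2 keeps chloro at that place. Nothing at hand bears on why methyl and chloro differ here.

On these data alone, whether ethyl or methoxy in place of the methyl lowers the number further remains open, as does the effect of an amine there.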